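The source may hold more compounds than are shown below. What is called first, only, known or untested is meant among the compounds shown, and "the series" means these compounds.

Working notes on the series. Compound 1 `CC(=O)OC/C1=C/C[C@](C)(CCC=C(C)C)/C=C/[C@@H](OC(=O)C=C(C)C)[C@](C)(OC(C)=O)/C=C/C1=O` gives 4130 nM in a functional assay on SMMC-7721 cells (Homo sapiens) for antiproliferative activity, read by MTT assay, with a stated time of 48 h; a higher number here means a weaker inhibitor, a lower number a stronger inhibitor. Compound 2 `CC(C)=CCC[C@]1(C)/C=C/[C@@H](OC(=O)C=C(C)C)[C@](C)(O)/C=C/C(=O)/C(CN(C(C)C)C(C)C)=C\C1` gives 340 nM in this assay, the lowest of the three numbers here; compound 3 `CC(C)=CCC[C@]1(C)/C=C/[C@@H](OC(=O)C=C(C)C)[C@](C)(O)/C=C/C(O)/C(C=O)=C\C1` gives 730 nM, which puts it nearest to compound 2 but still beyond the usual scatter, while compound 1 stands furthest away. Within the data shown here, no two measured compounds differ in a single place, so no one-change step can be drawn from the data. Compound 4 `CC(C)=CCC[C@]1(C)/C=C/[C@@H](OC(=O)C=C(C)C)[C@](C)(O)/C=C/C(=O)/C(C(=O)N2CCCC2)=C\C1` differs from compound 2 by (pyrrolidin-1-yl)carbonyl in place of (diisopropylamino)methyl on a double-bonded ring carbon. Among the measured compounds shown here, with no comparable step to lean on, only a modest weakening is expected, on the order of a 1.8-fold higher number from compound 2 to compound 4 (0.25 log units; within the scatter). For compound 4 the estimate is 600 nM, within a range of 200 nM to 2000 nM.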

Compound 4, half-maximal inhibitory concentration: 14900 nM
The estimate for compound 4 lay 25-fold (1.40 log units) below the measured number; the whole stated range lies below it.
By their numbers in this assay, from the lowest: compound 2; then compound 3; then compound 1; then compound 4.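

In this assay, among these compounds, the first one-change step shows that this double-bonded ring carbon is far from indifferent to its substituent: (pyrrolidin-1-yl)carbonyl in place of (diisopropylamino)methyl gives a 44-fold higher number from compound 2 to compound 4 (1.64 log units; beyond the scatter). On the shared core, the group at this place alone can therefore shift the number by a large margin. No measurement bears on the reason for this step.

From the compounds shown here alone, the step changes the carbonyl and the amine part together, so the contribution of each remains open. A (pyrrolidin-1-yl)methyl group or a diisopropylamide at this place would separate them.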